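The compounds below may be only part of what the source reports. "The series", "measured", "known", "first", "only" and "open" are said of these compounds alone.

Measured so far:
- compound 1, `COCCN/C(=C1/N=CN(CCOC)C1=O)c1cc2cccnc2[nH]1`: 79.4%
- compound 2, `O=C1/C(=C(\NCc2ccccc2)c2cc3cccnc3[nH]2)N=CN1Cc1ccccc1`: 11.7%

Both numbers come from an assay on isolated protein for inhibition of Calpain-1 catalytic subunit (Homo sapiens), read by fluorescence, with a stated time of 60 min, tested at 1 uM; a lower number here means less inhibition, a higher number more inhibition at the concentration tested (going by the name of the read-out). For the measured compounds named here, of the two, compound 2 stands lowest; its only neighbour is compound 1, whose number lies higher by a gap well beyond the usual scatter of repeated measurements. Going by the values given here, no two measured compounds differ in just one place, so no single structural step has a measured size here, and the two values can only be set side by side.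

Compound 3, `O=C1/C(=C(\NCc2ccccc2)c2cc3ccccc3[nH]2)N=CN1Cc1ccccc1`, has not yet been measured. It differs from compound 2 in one place: a group of 9 heavy atoms (8 carbon, 1 nitrogen; one five-membered aromatic ring with 1 hetero atom, one six-membered aromatic ring of carbon only) in place of a group of 9 heavy atoms (7 carbon, 2 nitrogen; one five-membered aromatic ring with 1 hetero atom, one six-membered aromatic ring with 1 hetero atom), on a double-bonded chain carbon bound to an amine nitrogen and a double-bonded ring carbon. Nothing measured shows what this exchange does on this core, so the expectation leans on compound 2 itself and on the modest nature of the change. The step from compound 2 to compound 3 is expected to be a number 2.3 percentage points higher from compound 2 to compound 3 (within the scatter), which would stay within the scatter, with no clear direction. Compound 3 is therefore estimated at 14%, in a range from 0% to 35%.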

Compound 3, a percentage reported as inhibition, at one concentration (the size of the read-out at that concentration, not a potency): 28.2%
For compound 3 the middle estimate is 14.2 percentage points below the measured one; the measured number falls inside the stated range.
By their numbers in this assay, from the lowest: compound 2; then compound 3; then compound 1.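

In this assay, for the compounds shown here, putting 1H-indol-2-yl on the double-bonded chain carbon bound to an amine nitrogen and a double-bonded ring carbon gives a number 16.5 percentage points higher from compound 2 to compound 3 (beyond the scatter), and this is the first single change in the set whose size can be read. It shows that this position is sensitive to a small exchange: the number of heavy atoms stays the same and both groups keep a five-membered and a six-membered aromatic ring, yet a ring nitrogen replaced by carbon, which also removes one counted hydrogen-bond acceptor, moves the number beyond the usual scatter. No measurement here explains why the number rises with this exchange.

Compound 1 differs from compound 2 and compound 3 in more than one place, so the compounds shown cannot tell whether 1H-indol-2-yl would give a similar rise with the side chains of compound 1. They also leave open what a phenyl ring, a benzofuran-2-yl group or a 1H-benzimidazol-2-yl group would do on the same chain carbon, and whether a rise seen at a single tested concentration would carry over to a true measure of potency.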